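Chloro in place of fluoro: little change expected

This account rests on a few compounds, and the source may have more. Where it says the series, first, only, none or still open, it means among the compounds named here.

In a functional assay on Jurkat cells (Homo sapiens) for antiproliferative activity, with a stated time of 48 h (a higher number here means that more compound is needed for the effect, a lower number that less compound is needed), compound 1 (`O=C(CCCCCCC(=O)Nc1cccc(F)c1)NO`) gives 640 nM and lies within the scatter of its two measured relatives. Compound 2 (`O=C(CCCCCCC(=O)Nc1ccc(C(F)(F)F)cc1)NO`) gives 530 nM and compound 3 (`O=C(CCCCCCC(=O)Nc1ccc(Cl)cc1)NO`) gives 770 nM on the same test. Compound 4 (`O=C(CCCCCCC(=O)Nc1cccc(Cl)c1)NO`) is still unmeasured. Its change from compound 1 is chloro in place of fluoro on an aromatic carbon and amounts to chloro in place of fluoro on an aromatic carbon. Within the data shown here, only one measured step bears on this, a 1.5-fold higher number from compound 2 to compound 3 (0.16 log units; within the scatter), which also brings in chloro, though it replaces trifluoromethyl rather than fluoro. Among the measured compounds shown here, no measured pair swaps fluoro for chloro directly. No step beyond the scatter is therefore expected in this assay, and the expected step is a 1.1-fold lower number from compound 1 to compound 4 (0.03 log units; within the scatter) at most a small one. Compound 4 is estimated at 600 nM with an expected range from 300 nM to 1200 nM on this test.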

Compound 4, half-maximal effective concentration: 580 nM
The estimate for compound 4 lay 1.0-fold (0.01 log units) above the measured number; the measured number falls inside the stated range.
By their numbers in this assay, from the lowest: compounds 2, 4, 1 and 3 (each within the scatter of the next).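

In this assay, chloro in place of fluoro on this aromatic carbon, meta to a large group, gives a 1.1-fold lower number from compound 1 to compound 4 (0.04 log units; within the scatter). Among these compounds, this is the first direct comparison of these two groups in one place, and it shows that the assay does not separate them here. No measurement available explains this result.

Going by these compounds, what an amine or a carboxylic acid would do on this aromatic carbon stays open. So does whether this swap would remain as small with a longer chain in the shared core.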